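The source may hold more compounds than are shown below. What is called first, only, known or untested is meant among the compounds shown, and "the series" means these compounds.

Working notes on the series. Among the compounds with values here, in a functional assay on HT-29 cells (Homo sapiens) for inhibition, read by luminescence and CellTiter-Glo, with a stated time of 12 h (a lower number here means that less compound is needed, a higher number that more compound is needed for the effect), compound 2 `CCOC(=O)c1cccc(NC(=O)Nc2cc(Oc3ccc4nc(NC(=O)C5CC5)sc4c3)ccc2F)c1` gives 7740 nM; this is the only number in the set. Compound 1 `O=C(Nc1nc2ccc(Oc3ccc(F)c(NC(=O)C4(c5cccc(C(F)(F)F)c5)CC4)c3)cc2s1)C1CC1` returns only a limit, > 20000 nM, which is the limit of > 20000 nM in this assay, at which 1 of the 2 values shown sits. Compound 3 `CC(=O)c1cccc(NC(=O)Nc2cc(Oc3ccc4nc(NC(=O)C5CC5)sc4c3)ccc2F)c1` differs from compound 2 by methyl in place of ethoxy on a carbonyl carbon. Within the data shown here, no measured pair shows the effect of this change, so the step in this assay is expected to be small, a 1.0-fold higher number from compound 2 to compound 3 (0.01 log units; within the scatter), with no clear direction beyond the scatter. Compound 3 is estimated at 8000 nM in this assay, within 2500 nM to 25000 nM.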

Compound 3, half-maximal effective concentration: 1000 nM
Compound 3: middle estimate off by 8.0-fold (0.90 log units), on the high side, outside the stated range (below it).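

In this assay, replacing ethoxy with methyl on the carbonyl carbon is not a neutral swap: it gives a 7.7-fold lower number from compound 2 to compound 3 (0.89 log units; beyond the scatter), so this position responds to the group on that carbonyl carbon. Within the data shown here, this is the first step that can be read from a pair differing in one place. Nothing measured in the set accounts for the size of this step. As far as these compounds go, it remains open whether an amine or a hydroxyl on the same carbonyl carbon, or a longer chain such as propyl, would move the number further in either direction.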